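A few compounds are considered here, and "the series" means these few. Any claim that something is new, unique, unknown or untested is made for them only; others in the source may bear on it.

Measured so far in a functional assay on MCF7 cells (Homo sapiens) for antiproliferative activity, read by MTT assay, with a stated time of 48 h; a lower number here means a stronger inhibitor, a higher number a weaker inhibitor:
compound 1 `Cc1cccc(-c2nn(-c3ccccc3)cc2C(Nc2nc3ccccc3s2)c2c(O)ccc3ccccc23)c1`: 17300 nM
compound 2 `COc1ccc2nc(NC(c3cn(-c4ccccc4)nc3-c3ccc(F)cc3)c3c(O)ccc4ccccc34)sc2c1`: 16900 nM
compound 3 `Oc1ccc2ccccc2c1C(Nc1nc2ccc(Cl)cc2s1)c1cn(-c2ccccc2)nc1-c1ccc(F)cc1`: 21600 nM

Compound 3 at 21600 nM stands level with the other two, as all three values lie within the scatter of one another. The next compound is compound 4 `O=[N+]([O-])c1ccc(-c2nn(-c3ccccc3)cc2C(Nc2nc3ccc(Cl)cc3s2)c2c(O)ccc3ccccc23)cc1`, with nitro in place of fluoro on an aromatic carbon.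

Among the compounds with values here, no measured step covers this change. Within the data shown here, the only measured step, a 1.3-fold higher number from compound 2 to compound 3 (0.11 log units; within the scatter), is chloro in place of methoxy and stays within the scatter. Compound 1 carries no fluoro, chloro or methoxy, yet compound 1 gives 17300 nM, again within the scatter of the others. Among the measured compounds shown here, this is thin evidence, and no measured compound carries nitro.

In this assay no step beyond the scatter is therefore expected, and no direction can be firmly supported. The expected step is a 1.3-fold lower number from compound 3 to compound 4 (0.10 log units; within the scatter). For compound 4 the estimate is 17000 nM, with an expected range of 7500 nM to 34000 nM.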

Compound 4, half-maximal inhibitory concentration: 38600 nM
Compound 4: middle estimate off by 2.3-fold (0.36 log units), on the low side; the measured number lies above the stated range.
By their numbers in this assay, from the lowest: compounds 2, 1, 3 and 4 (each within the scatter of the next, the first and the last beyond it).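

In this assay, within the data shown here, the change from 4-fluorophenyl to 4-nitrophenyl gives a 1.8-fold higher number from compound 3 to compound 4 (0.25 log units; within the scatter) and is the only measured change at this aromatic carbon, para to a large group. Nitro, with 3 heavy atoms and 2 hydrogen-bond acceptors, thus replaces fluoro, with 1 heavy atom and 0 hydrogen-bond acceptors, without a step beyond the scatter, so this place accepts the larger group in this one matched pair. No measurement at hand bears on what lies behind the size of this step.

Going by these compounds, whether an amine or a carboxylic acid on the same carbon would give a step beyond the scatter remains open. Also open, on these data alone, is whether the same change reads alike with methoxy in place of chloro on the other side of the molecule.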